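The source may report more compounds than this note shows. Statements on the series, on what has been measured and on what is new or still open speak of the compounds shown alone.

Measured compounds:
Compound 1, `O=C([C@@H]1C[C@H]1c1ccccc1)N(CC1CCCNC1)c1ccc(-c2ccccc2)cc1`: 10 nM
Compound 2, `CC(C)C[C@H](N)CN(C(=O)[C@@H]1C[C@H]1c1ccccc1)c1ccc(-c2cccnc2)cc1`: 10000 nM
Compound 3, `CC[C@H](C)[C@H](N)CN(C(=O)[C@@H]1C[C@H]1c1ccccc1)c1ccc(-c2ccc(Oc3ccccc3)cc2)cc1`: 94 nM

All three were examined in a functional assay for agonist activity at G protein-coupled receptor 88 (Homo sapiens), read by HTRF and cAMP accumulation; on this read-out lower numbers stand for an effect already at smaller amounts and higher numbers for an effect only at larger amounts of compound. Compound 3 stands second highest of the three numbers there. Its nearest neighbour is compound 1, whose value of 10 nM is the lower number by a margin beyond the scatter; compound 2, at 10000 nM, stands furthest from it with a much higher number, again beyond the scatter. Compound 3 is thus neither the strongest nor the weakest of the set, but it lies closer to compound 1.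

Compound 4 `CC[C@H](C)[C@H](N)CN(C(=O)[C@@H]1C[C@H]1c1ccccc1)c1ccc(-c2ccc(CN)cc2)cc1` has not yet been measured. It differs from compound 3 in a single place: aminomethyl in place of phenoxy on an aromatic carbon. A two-heavy-atom aminomethyl thus replaces a seven-heavy-atom phenoxy. Among the measured compounds shown here, no measured pair shows this very change, so no step of this kind can be consulted. Compound 1, which carries neither group, gives 10 nM, while compound 2, with a different ring and a different amine, gives 10000 nM. The expected step of a 2.1-fold higher number from compound 3 to compound 4 (0.33 log units; beyond the scatter) in this assay is therefore modest and uncertain, with a somewhat higher number judged slightly more likely than a lower one. Compound 4 is estimated at 200 nM, with a range from 30 nM to 1500 nM.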

Compound 4, half-maximal effective concentration: > 30000 nM
Compound 4: only a limit was reported; the forecaster's own chance of this, stated with the estimate: 10%; middle value at least 150-fold (2.17 log units) away from the limit.
By their numbers in this assay, from the lowest: compound 1; then compound 3; then compound 2. At a limit, above all of these: compound 4.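

In this assay, this position proves far from indifferent: aminomethyl in place of phenoxy on an aromatic carbon, para to a large group, gives an at least 310-fold higher number from compound 3 to compound 4 (2.50 log units; beyond the scatter), a step that takes away a six-membered aromatic ring of carbon only and brings in a hydrogen-bond donor. The value of compound 4, > 30000 nM, is a limit and not a number. The step therefore gives a lower bound on the change and not its measured size: the limit of > 30000 nM in this assay, at which 1 of the 4 values shown sits.

Whether the loss of the ring or the arrival of the aminomethyl group accounts for the step stays open; the two change together in this single pair, and no other compound shown separates them. Also open, as far as these compounds go, is how a methoxy, a benzyloxy or a hydroxymethyl group on the same aromatic carbon would stand in this assay, and whether a longer amine chain, such as aminoethyl, or a carboxylic acid there would give a measurable value.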